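The compounds below may be only part of what the source reports. "The series", "measured", "known", "first", "only" and "open" are said of these compounds alone.

Compound 1 `CC(=O)Nc1cc(NC(=O)c2ccc(Cl)c(C(F)(F)F)c2)ccc1C`: > 30000 nM
Compound 2 `Cc1ccc(NC(=O)c2cc(C(F)(F)F)cc(C(F)(F)F)c2)cc1NC(=O)c1ccccc1`: > 30000 nM

In a functional assay on A375P cells (Homo sapiens) for antiproliferative activity (on this read-out lower numbers stand for stronger inhibition and higher numbers for weaker inhibition), compound 1 gives > 30000 nM, which is a limit of the assay rather than a number. Compound 2 likewise gives > 30000 nM, also a limit. Compound 1 therefore stands at the limit of > 30000 nM in this assay, at which 2 of the 2 values shown sit. The unmeasured compound 3 `Cc1ccc(NC(=O)c2ccc(Cl)c(C(F)(F)F)c2)cc1NC(=O)c1ccccc1` differs from compound 1 by phenyl in place of methyl on a carbonyl carbon. Among the compounds with values here, no measured pair shows this change. Since both measured compounds sit at the limit, no step beyond the scatter is expected. Compound 3 is estimated to show a step of a number no higher from compound 1 to compound 3 (the limit leaves the size open). For compound 3 the expected value is 30000 nM, within a range of 10000 nM to 100000 nM, most likely again reported only as a limit.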

Compound 3, half-maximal inhibitory concentration: > 30000 nM
Compound 3: a limit, no number (the forecaster's own chance of this, stated with the estimate: 80%); the middle value lies on the limit itself.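

Within the data shown here, no step from compound 1 to compound 3 can be read, since both results are limits rather than numbers: the limit of > 30000 nM in this assay, at which 3 of the 3 values shown sit. The compounds shown leave open what change to the shared core would give a measurable value.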